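A few compounds are considered here, and "the series" means these few. Any claim that something is new, unique, unknown or untested is made for them only; others in the source may bear on it.

Compound 1 `CN1CCN(Cc2ccc(NC(=O)Nc3ccc4ncnc(Nc5ccc(F)c(Cl)c5)c4c3)cc2)CC1` gives 3480 nM in a functional assay on A549 cells (Homo sapiens) for antiproliferative activity, read by MTT assay, with a stated time of 72 h; a higher number here means a weaker inhibitor, a lower number a stronger inhibitor. Compound 2 `CN1CCN(Cc2ccc(NC(=O)Nc3ccc4ncnc(Nc5ccc(F)c(F)c5)c4c3)cc2)CC1` returns only the assay limit, > 10000 nM, in this assay. The step of an at least 2.8-fold higher number from compound 1 to compound 2 (0.45 log units; beyond the scatter) therefore rests on (the limit of > 10000 nM in this assay, at which 1 of the 3 values shown sits). Compound 3 `O=C(Nc1ccc(CN2CCCC2)cc1)Nc1ccc2ncnc(Nc3cccc(C(F)(F)F)c3)c2c1` gives 830 nM in this assay, the lowest number shown, with compound 1 the nearest. Compound 4 `Cc1ccc(NC(=O)Nc2ccc3ncnc(Nc4cccc(C(F)(F)F)c4)c3c2)cc1` differs from compound 3 by hydrogen in place of pyrrolidin-1-yl on a saturated chain carbon bound to an aromatic carbon. Among the compounds with values here, no measured step touches a saturated chain carbon; the single measured step is a halogen swap on an aromatic carbon, and compounds 1 and 3 differ in more than one place, so their two values only show that compound 3 sits lower. The estimated step is a 3.6-fold higher number from compound 3 to compound 4 (0.56 log units; beyond the scatter), toward a higher number. Compound 4 is expected at 3000 nM, range 700 nM to 12000 nM.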

Compound 4, half-maximal inhibitory concentration: 4140 nM
The estimate for compound 4 lay 1.4-fold (0.14 log units) below the measured number, within the range that was stated.
By their numbers in this assay, from the lowest: compound 3; then compounds 1 and 4 (each within the scatter of the next). At a limit, above all of these: compound 2.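

In this assay, within the data shown here, hydrogen in place of pyrrolidin-1-yl on a saturated chain carbon bound to an aromatic carbon gives a 5.0-fold higher number from compound 3 to compound 4 (0.70 log units; beyond the scatter), the only measured step at this place. In this pair, the change from 4-((pyrrolidin-1-yl)methyl)phenyl to 4-methylphenyl therefore matters beyond the scatter, whereas the earlier step covered only a halogen swap on an aromatic carbon. Nothing measured here gives a reason for this step.

From the compounds shown here alone, whether a dimethylamino group or a carboxylic acid on that carbon would keep the lower number remains open. Also open, going by these compounds, is whether the step keeps its size with the other substituents on the shared core.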